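(3,4-Dichlorophenyl)amino to phenyl: estimate for compound 4

The source may report more compounds than this note shows. Statements on the series, on what has been measured and on what is new or still open speak of the compounds shown alone.

Measured so far:
compound 1 `COc1cc(-c2nn(-c3cccc(NC(=O)Nc4ccc(Cl)c(Cl)c4)c3)cc2-c2ccncc2)ccc1Cl`: 2420 nM
compound 2 `O=C(Nc1cccc(-n2cc(-c3ccncc3)c(-c3ccc(Cl)c(O)c3)n2)c1)Nc1ccc(Cl)c(Cl)c1`: 8100 nM
compound 3 `O=C(Nc1cccc(-n2cc(-c3ccncc3)c(-c3ccc(Cl)c(O)c3)n2)c1)Nc1cc(C(F)(F)F)cc(C(F)(F)F)c1`: 3030 nM

In a functional assay on Malme-3M cells (Homo sapiens) for inhibition, read by sulforhodamine B assay, with a stated time of 48 h (on this read-out higher numbers stand for weaker inhibition of growth and lower numbers for stronger inhibition of growth), compound 1 gives 2420 nM. Compound 3 gives 3030 nM, a gap within the scatter of compound 1, while compound 2 gives 8100 nM, beyond the scatter from compound 1. For the measured compounds named here, the only single-point step measured, a 3.3-fold higher number from compound 1 to compound 2 (0.52 log units; beyond the scatter), concerns the oxygen on the aromatic ring and does not bear on compound 4 `COc1cc(-c2nn(-c3cccc(NC(=O)c4ccccc4)c3)cc2-c2ccncc2)ccc1Cl`, whose change from compound 1 is phenyl in place of (3,4-dichlorophenyl)amino on a carbonyl carbon. Going by the values given here, no measured step covers this change, so the expectation rests on compound 1 alone and is uncertain. Compound 4 is expected to give a modestly higher number, a 2.9-fold higher number from compound 1 to compound 4 (0.46 log units; beyond the scatter), estimated at 7000 nM with a range of 2000 nM to 25000 nM.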

Compound 4, concentration for total growth inhibition: > 100000 nM
Compound 4 was reported as a limit; the forecaster's own chance of this, stated with the estimate: 10%; at least 14-fold (1.15 log units) between middle value and limit.
By their numbers in this assay, from the lowest: compounds 1 and 3 (each within the scatter of the next); then compound 2. At a limit, above all of these: compound 4.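

On this carbonyl carbon, phenyl in place of (3,4-dichlorophenyl)amino gives an at least 41-fold higher number from compound 1 to compound 4 (1.61 log units; beyond the scatter) in this assay, a larger step than the one at the oxygen on the aromatic ring, a 3.3-fold higher number from compound 1 to compound 2 (0.52 log units; beyond the scatter). Compound 4 is reported only as a limit of the assay, and it stands alone there: the limit of > 100000 nM in this assay, at which 1 of the 4 values shown sits.

The change removes the nitrogen and both chlorines at once, and the compounds shown do not separate their contributions. Going by these compounds, whether phenylamino without chlorine, or benzyl, on the same carbonyl carbon restores growth inhibition remains open.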